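A few compounds are considered here, and "the series" means these few. Any claim that something is new, unique, unknown or untested is made for them only; others in the source may bear on it.

Measured so far in a functional assay on HeLa cells (Homo sapiens) for antiproliferative activity, read by sulforhodamine B assay, with a stated time of 48 h; on this read-out higher numbers stand for weaker inhibition and lower numbers for stronger inhibition: compound 1 `COc1cc(OC)c2sc(-c3ccc(N/C=C\C(=O)c4ccc(OC)c([N+](=O)[O-])c4)c(C)c3)nc2c1` with 9390 nM; compound 2 `COc1cc(OC)c2sc(-c3ccc(N/C=C\C(=O)c4cc(OC)c(OC)c(OC)c4Br)c(C)c3)nc2c1` with 14700 nM; compound 3 `COc1cc(OC)c2sc(-c3ccc(N/C=C\C(=O)c4cc(OC)c(OC)c([N+](=O)[O-])c4)c(C)c3)nc2c1` with 11400 nM.

Compound 3 differs from compound 1 by methoxy in place of hydrogen on an aromatic carbon, and that step was a 1.2-fold higher number from compound 1 to compound 3 (0.08 log units; within the scatter). How the core of compound 2 differs from the core of compound 1 is not broken down here. Compound 4 `COc1cc(C(=O)/C=C\Nc2ccc(-c3nc4cc(OC)c(OC)c(OC)c4s3)cc2C)c(Br)c(OC)c1OC` differs from compound 2 by methoxy in place of hydrogen on an aromatic carbon, the same kind of change as from compound 1 to compound 3, though the surroundings differ: in compound 4 the ring is part of a fused or bridged system of two rings and the carbon is ortho to two methoxy groups, meta to a fused ring and para to a fused ring, whereas in compound 3 it is ortho to a methoxy group, meta to a large group and meta to a nitro group. Because the earlier step was a 1.2-fold higher number from compound 1 to compound 3 (0.08 log units; within the scatter), compound 4 is expected to move by a 1.1-fold higher number from compound 2 to compound 4 (0.04 log units; within the scatter) in this assay. Compound 4 is estimated at 16000 nM, between 7500 nM and 34000 nM.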

Compound 4, half-maximal inhibitory concentration: 14300 nM
For compound 4 the middle estimate is 1.1-fold (0.05 log units) above the measured one, within the range that was stated.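

Methoxy in place of hydrogen on an aromatic carbon gave a 1.0-fold lower number from compound 2 to compound 4 (0.01 log units; within the scatter) in this assay, so the step was again small. Set beside the earlier step, the change reads the same on both cores, with no difference that can be told apart: the same change on two cores in this assay, a 1.2-fold higher number (0.08 log units; within the scatter) from compound 1 to compound 3 and a 1.0-fold lower number (0.01 log units; within the scatter) from compound 2 to compound 4, 1.2-fold (0.10 log units) apart, within the scatter of two such steps. This shows that on these two cores the change left the numbers within the scatter, but it does not show that methoxy has any effect of its own here, and two pairs say nothing about other cores in the series.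

The compounds shown leave open whether an amine, a carboxylic acid or a longer chain such as ethoxy at this carbon would move the number in this assay any further. They also leave open whether a step beyond the scatter can be found at this place at all.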